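The source may report more compounds than this note shows. Statements on the series, on what has been measured and on what is new or still open speak of the compounds shown alone.

In an ADME assay on MT4 cells (Homo sapiens) for cytotoxicity, read by MTT assay, with a stated time of 4 days (on this read-out lower numbers stand for higher toxicity in this test and higher numbers for lower toxicity in this test), compound 3 `Cc1ccc(-c2c(C)c(-c3ccc(Cl)c(F)c3)c(C(OC(C)(C)C)C(=O)O)c(C)c2NS(C)(=O)=O)cc1C` gives 22000 nM. Compound 1 `Cc1ccc(-c2c(C)c(-c3ccc4c(c3C)CCCO4)c(C(OC(C)(C)C)C(=O)O)c(C)c2NS(C)(=O)=O)cc1C` gives 24000 nM, and the two sit within the scatter of each other: a 1.1-fold lower number from compound 1 to compound 3 (0.04 log units; within the scatter). Compound 2 `Cc1ccc(-c2c(C)c(-c3ccccc3)c(C(OC(C)(C)C)C(=O)O)c(C)c2NS(C)(=O)=O)cc1C` returns only a limit of the assay, > 50000 nM.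

Compound 4 `Cc1ccc(-c2c(C)c(-c3ccc(Cl)cc3)c(C(OC(C)(C)C)C(=O)O)c(C)c2NS(C)(=O)=O)cc1C` has hydrogen in place of fluoro on an aromatic carbon, ortho to a chloro group: hydrogen in place of fluoro on an aromatic carbon. This takes 4-chloro-3-fluorophenyl to 4-chlorophenyl.

The nearest measured evidence is an at least 2.2-fold lower number from compound 2 to compound 3 (0.35 log units; beyond the scatter), with 4-chloro-3-fluorophenyl in place of phenyl. That step changes chloro and fluoro together, and its size is only bounded. Going by the values given here, no measured step changes fluoro alone. Compound 4 keeps the chloro group, so in this assay a small upward move at most is expected, probably not beyond the scatter. The estimate amounts to a 1.3-fold higher number from compound 3 to compound 4 (0.10 log units; within the scatter), an expected step and not a measured one. For compound 4 the expected value is 28000 nM, with an estimated range of 15000 nM to 50000 nM.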

Compound 4, half-maximal cytotoxic concentration: 26000 nM
Compound 4: middle estimate off by 1.1-fold (0.03 log units), on the high side; measured number inside the range.
By their numbers in this assay, from the lowest: compounds 3, 1 and 4 (each within the scatter of the next). At a limit, above all of these: compound 2.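

Hydrogen in place of fluoro, ortho to a chloro group, gives no readable change in this assay (a 1.2-fold higher number from compound 3 to compound 4 (0.07 log units; within the scatter)), and 4-chlorophenyl also stays level with the larger group on compound 1 (a 1.1-fold higher number from compound 1 to compound 4 (0.03 log units; within the scatter)). Chloro in place of hydrogen now appears as a single change, separated from the earlier paired change of chloro and fluoro (an at least 1.9-fold lower number from compound 2 to compound 4 (0.28 log units; that floor lies within the scatter)), but that floor does not establish a step beyond the scatter. Compound 2 stands at a limit of the assay, so the true size of this step cannot be read (limit: the limit of > 50000 nM in this assay, at which 1 of the 4 values shown sits).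

The compounds shown leave open what a fluoro group does on the phenyl ring without the chloro group. They also leave open how an amine or a methoxy group would read in place of the chloro group.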